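The source may hold more compounds than are shown below. What is called first, only, known or untested is meant among the compounds shown, and "the series" means these compounds.

Measured compounds in a functional assay on NCI-H460 cells (Homo sapiens) for cytotoxicity, read by MTT assay, with a stated time of 72 h; on this read-out lower numbers stand for stronger inhibition and higher numbers for weaker inhibition:
compound 1 `CN(C)CCCNc1nc(-c2ccc(NC(=O)Nc3ccc(F)cc3)cc2)nc2c(Cl)c(Cl)sc12` — 650 nM
compound 2 `CN(C)CCCNc1nc(-c2ccc(NC(=O)Nc3ccccc3Cl)cc2)nc2c(Cl)c(Cl)sc12` — 490 nM

Among the compounds with values here, compound 1 gives the highest of the two numbers so far; its nearest neighbour is compound 2, and the step of a 1.3-fold lower number from compound 1 to compound 2 (0.12 log units; within the scatter) lies within the scatter, so the two are not distinguishable on this read-out.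

Compound 3 `CN(C)CCNc1nc(-c2ccc(NC(=O)Nc3ccc(F)cc3)cc2)nc2c(Cl)c(Cl)sc12` is not yet measured. It differs from compound 1 at the chain on the amine attached to the shared core: dimethylamino in place of (dimethylamino)methyl on a saturated chain carbon, two bonds along the chain from a nitrogen on an aromatic ring. Read one bond further out, the change is from 3-(dimethylamino)propyl to 2-(dimethylamino)ethyl, the terminal dimethylamino being kept.

Within the data shown here, the only measured step, from compound 1 to compound 2, concerns the aryl on the urea and not the chain, so it gives no direct guidance on this change. With nothing in the series touching the chain, no step beyond the scatter is assumed in either direction. Compound 3 is therefore expected near compound 1, estimated at 700 nM with a range of 300 nM to 1700 nM, which corresponds to an expected step of a 1.1-fold higher number from compound 1 to compound 3 (0.03 log units; within the scatter).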

Compound 3, half-maximal inhibitory concentration: 590 nM
Compound 3: the middle estimate sits 1.2-fold (0.07 log units) above what was measured; the range from low to high includes it.
By their numbers in this assay, from the lowest: compounds 2, 3 and 1 (each within the scatter of the next).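

In this assay shortening the chain on the amine of the shared core from 3-(dimethylamino)propyl to 2-(dimethylamino)ethyl, with the terminal dimethylamino kept, gives a 1.1-fold lower number from compound 1 to compound 3 (0.04 log units; within the scatter) and so does not separate the two chain lengths on this read-out. Within the data shown here, the earlier pair varied only the aryl on the urea, so this is the first reading on the chain: on a saturated chain carbon, two bonds along the chain from a nitrogen on an aromatic ring, the change from (dimethylamino)methyl to dimethylamino leaves no difference that can be told from the scatter, and this holds so far only with the 4-fluorophenyl on the urea. No measurement at hand bears on the reason for this result.

Still open, on these data alone, is whether a longer chain carrying the same terminal dimethylamino, or a chain ending in a primary amine or a carboxylic acid in place of the dimethylamino, would read the same as compound 1 and compound 3. Also open, as far as these compounds go, is whether 2-(dimethylamino)ethyl reads the same when combined with the 2-chlorophenyl on the urea of compound 2.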